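The compounds below may be only part of what the source reports. "The series", "measured", "known", "first", "only" and "open" are said of these compounds alone.

Measured compounds: compound 1 `O=c1c(CSC(=S)N2CCOCC2)coc2cc(Cl)ccc12` gives 6200 nM in a functional assay on SW480 cells (Homo sapiens) for antiproliferative activity, read by MTT assay, with a stated time of 72 h; on this read-out lower numbers stand for stronger inhibition and higher numbers for weaker inhibition; compound 2 `O=c1c(CSC(=S)N2CCCCC2)coc2cc(Cl)ccc12` gives 790 nM; compound 3 `O=c1c(Cl)c(CSC(=S)N2CCOCC2)oc2ccccc12` gives 1800 nM.

Compound 1 stands highest of these three numbers. Among the measured compounds shown here, its nearest neighbour is compound 3, and compound 2 lies furthest from it, the one measured step being a 7.8-fold lower number from compound 1 to compound 2 (0.89 log units; beyond the scatter). Compound 4 `O=c1c(CSC(=S)N2CCOCC2)coc2ccccc12` differs from compound 1 by hydrogen in place of chloro on an aromatic carbon. For the measured compounds named here, none of the measured steps bears on this change: the step from compound 1 to compound 2 alters the group on the thiocarbonyl carbon, and compound 3 shares no single-point relation with compound 1. With no guide, the expected step is none beyond the scatter, a 1.0-fold lower number from compound 1 to compound 4 (0.01 log units; within the scatter). Compound 4 is therefore estimated at 6000 nM, within 2000 nM to 18000 nM.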

Compound 4, half-maximal inhibitory concentration: 5900 nM
Estimate against measurement, compound 4: 1.0-fold (0.01 log units) above, and the stated range covers the measured number.
By their numbers in this assay, from the lowest: compound 2; then compound 3; then compounds 4 and 1 (each within the scatter of the next).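

In this assay, hydrogen in place of chloro on this aromatic carbon gives a 1.1-fold lower number from compound 1 to compound 4 (0.02 log units; within the scatter), so with morpholin-4-yl on the thiocarbonyl carbon, the chloro group at this position makes no difference beyond the scatter. Among the compounds shown here, this is the first reading at this position, as the earlier step changed only the group on the thiocarbonyl carbon. No evidence is available that bears on this result. The compounds shown leave open whether this change reads the same with piperidin-1-yl on the thiocarbonyl carbon, and whether a methoxy group or an amine on this aromatic carbon would shift the number beyond the scatter.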